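Chloro and bromo benzyl variants on one core

The compounds below may be only part of what the source reports. "The series", "measured", "known", "first", "only" and "open" are said of these compounds alone.

Measured so far:
compound 1 `Cc1cc(Nc2nc(NCc3ccccc3Cl)nc3[nH]ncc23)n[nH]1`: 668 nM
compound 2 `Cc1cc(Nc2nc(NCc3ccccc3Br)nc3[nH]ncc23)n[nH]1`: 1090 nM
compound 3 `Cc1cc(Nc2nc(NCc3ccc(Cl)cc3)nc3[nH]ncc23)n[nH]1`: 515 nM

All three were run in an assay on isolated protein for inhibition of serine/threonine-protein kinase PAK 4 (Homo sapiens), read by HTRF, with a stated time of 60 min; on this read-out higher numbers stand for weaker inhibition and lower numbers for stronger inhibition. Compound 1 and compound 2 differ by bromo in place of chloro on an aromatic carbon, a change that gave a 1.6-fold higher number from compound 1 to compound 2 (0.21 log units; within the scatter). Compound 1 and compound 3 differ in their cores by 4-chlorophenyl in place of 2-chlorophenyl on a saturated chain carbon bound to a nitrogen on an aromatic ring, with a 1.3-fold lower number from compound 1 to compound 3 (0.11 log units; within the scatter); compound 2 to compound 3 gave a 2.1-fold lower number from compound 2 to compound 3 (0.33 log units; beyond the scatter). Compound 3 has the lowest number of the three, but only its gap to compound 2 is beyond the scatter.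

Compound 4 `Cc1cc(Nc2nc(NCc3ccc(Br)cc3)nc3[nH]ncc23)n[nH]1` is not yet measured. It differs from compound 3 by bromo in place of chloro on an aromatic carbon. This is the same kind of change as that from compound 1 to compound 2, but the place differs: there the position was ortho to a large group, here it is para to a large group. For the measured compounds named here, on the core of compound 1 the change moved the number by a 1.6-fold higher number from compound 1 to compound 2 (0.21 log units; within the scatter); a step of about that size is expected here, a 1.4-fold higher number from compound 3 to compound 4 (0.15 log units; within the scatter), because a 1.6-fold higher number from compound 1 to compound 2 (0.21 log units; within the scatter) is the only precedent. Compound 4 is therefore estimated at 720 nM, expected between 350 nM and 1500 nM.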

Compound 4, half-maximal inhibitory concentration: 1320 nM
For compound 4 the middle estimate is 1.8-fold (0.26 log units) below the measured one; the measured number falls inside the stated range.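

Set side by side, bromo in place of chloro carries across the two cores with no gap beyond the scatter: the same change on two cores in this assay, a 1.6-fold higher number (0.21 log units; within the scatter) from compound 1 to compound 2 and a 2.6-fold higher number (0.41 log units; beyond the scatter) from compound 3 to compound 4, 1.6-fold (0.20 log units) apart, within the scatter of two such steps. Read alone, the 4-chlorobenzyl to 4-bromobenzyl change gives a 2.6-fold higher number from compound 3 to compound 4 (0.41 log units; beyond the scatter), but two pairs are too few to show that the change has a fixed size on every core, or that its size depends on the core. The replacements of 2-bromophenyl and 2-chlorophenyl by 4-bromophenyl give a 1.2-fold higher number from compound 2 to compound 4 (0.08 log units; within the scatter) and a 2.0-fold higher number from compound 1 to compound 4 (0.30 log units; within the scatter), so both lie within the scatter.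

The compounds shown leave open how fluoro, methoxy or trifluoromethyl in place of bromo would compare on these cores, and whether the change would carry to a core with a different group in place of the methyl on the shared core. They also leave open what an amine or a carboxylic acid on the benzyl ring would do to the number.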